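The source may report more compounds than this note shows. Statements on the series, on what has been measured and on what is new or still open speak of the compounds shown alone.

In a physicochemical assay for solubility, in phosphate buffer, at pH 7.4 (on this read-out lower numbers stand for lower solubility and higher numbers for higher solubility), compound 1 `CCOC(=O)c1c(-c2cccc(OC)c2)[nH]c2cc(OC)ccc2c1=O` reads > 100000 nM, which is a limit and not a number. Going by the values given here, compound 2 `CCOC(=O)c1c(-c2ccc(C(C)(C)C)cc2)[nH]c2cc(OC)ccc2c1=O` gives 2000 nM, the only actual number so far. Compound 3 `CCOC(=O)c1c(-c2ccc(OC)cc2)[nH]c2cc(OC)ccc2c1=O` differs from compound 2 by methoxy in place of tert-butyl on an aromatic carbon, para to a large group. Among the compounds with values here, no measured step covers this change. Compound 1 also carries methoxy rather than tert-butyl and reads > 100000 nM, so a rise well beyond the scatter is expected in this assay. The expected change is a 25-fold higher number from compound 2 to compound 3 (1.40 log units; beyond the scatter). Compound 3 is estimated at 50000 nM, within an expected range of 12000 nM to 100000 nM.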

Compound 3, solubility: 8000 nM
Compound 3: middle estimate off by 6.3-fold (0.80 log units), on the high side; the whole stated range lies above it.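

In this assay, methoxy in place of tert-butyl, para to a large group, gives a 4.0-fold higher number from compound 2 to compound 3 (0.60 log units; beyond the scatter), so this one pair shows the change raising the number. With methoxy kept, 4-methoxyphenyl in place of 3-methoxyphenyl gives an at least 12-fold lower number from compound 1 to compound 3 (1.09 log units; beyond the scatter), so the place of the methoxy on the ring also counts. That step is only a bound, since compound 1 stands at a limit: the limit of > 100000 nM in this assay, at which 1 of the 3 values shown sits.

The compounds shown leave open how an amine, a carboxylic acid or a chlorine at this place would read. Going by these compounds, whether the step holds with the ethyl ester replaced by an amide also stays open.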